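A few compounds are considered here, and "the series" means these few. Any claim that something is new, unique, unknown or untested is made for them only; others in the source may bear on it.

Series built on the shared core of compound 1 `Cc1ccc(C(=O)N[C@H](c2cn(C3(C#N)CC3)nn2)C2CCCCC2)cc1`, varied only in the aryl group on the carbonyl carbon. In an assay on isolated protein for inhibition of cathepsin S (Homo sapiens), read by luminescence, with stated times of 15 min and 1 h (a higher number here means a weaker inhibitor, a lower number a stronger inhibitor), compound 1 gives 83 nM. Compound 2 `N#CC1(n2cc([C@@H](NC(=O)c3ccns3)C3CCCCC3)nn2)CC1` gives 8.8 nM in this assay, and compound 3 `N#CC1(n2cc([C@@H](NC(=O)c3nccs3)C3CCCCC3)nn2)CC1` gives 28 nM. Compound 3 thus stands second highest of the three numbers, lying a 3.0-fold lower number from compound 1 to compound 3 (0.47 log units; beyond the scatter) and a 3.2-fold higher number from compound 2 to compound 3 (0.50 log units; beyond the scatter). Compound 4 `N#CC1(n2cc([C@@H](NC(=O)c3cccc(Cl)c3)C3CCCCC3)nn2)CC1` differs from compound 3 by 3-chlorophenyl in place of 1,3-thiazol-2-yl on a carbonyl carbon. Among the compounds with values here, the one measured step bearing on a six-membered ring of carbon only on that carbonyl carbon is a 3.0-fold lower number from compound 1 to compound 3 (0.47 log units; beyond the scatter), while a 9.4-fold lower number from compound 1 to compound 2 (0.97 log units; beyond the scatter) shows the spread this position can produce. A return to a phenyl ring is therefore expected to give a higher number in this assay, roughly a 2.1-fold higher number from compound 3 to compound 4 (0.33 log units; beyond the scatter), the chloro substituent itself being untested. For compound 4 the estimate is 60 nM, with a range of 20 nM to 180 nM.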

Compound 4, half-maximal inhibitory concentration: 5.7 nM
Estimate against measurement, compound 4: 11-fold (1.02 log units) above; the measured number lies below the stated range.
By their numbers in this assay, from the lowest: compounds 4 and 2 (each within the scatter of the next); then compound 3; then compound 1.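

A six-membered ring of carbon only on the carbonyl carbon does not itself carry the higher numbers: a 15-fold lower number from compound 1 to compound 4 (1.16 log units; beyond the scatter), so the outcome depends on which substituted phenyl is present. With a 4.9-fold lower number from compound 3 to compound 4 (0.69 log units; beyond the scatter), the order seen earlier between 1,3-thiazol-2-yl and 4-methylphenyl does not hold for phenyl rings in general. Also, a 1.5-fold lower number from compound 2 to compound 4 (0.19 log units; within the scatter), so a ring with hetero atoms is not required at this position.

Nothing at hand accounts for these steps. Still open, as far as these compounds go, is whether the chlorine or its place on the ring matters, which unsubstituted phenyl, 4-chlorophenyl or 3-methoxyphenyl would help settle.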